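A few compounds are considered here, and "the series" means these few. Any claim that something is new, unique, unknown or untested is made for them only; others in the source may bear on it.

In an ADME assay on HEK293 cells (Homo sapiens) for cytotoxicity, read by MTT assay, with a stated time of 24 h (a lower number here means a stronger inhibitor, a higher number a weaker inhibitor), compound 1 (`COC(=O)c1scc(-c2ccc(NC(=O)c3cccc(C(F)(F)F)c3)cc2)c1OC`) gives "not determined" (no result reported), so it has no number of its own. Its close relative compound 2 (`COC(=O)c1scc(-c2ccc(NC(=O)c3ccc(C(F)(F)F)cc3Br)cc2)c1OC`) reads > 50000 nM, and that is a limit of the assay, not a number. Among the compounds with values here, the only guide to where this series stands is therefore (the limit of > 50000 nM in this assay, at which 1 of the 2 values shown sits). Compound 3 (`COC(=O)c1scc(-c2ccc(NC(=O)c3ccc(OC)nc3)cc2)c1OC`) keeps the core of compound 1 but carries 6-methoxypyridin-3-yl in place of 3-(trifluoromethyl)phenyl on a carbonyl carbon. Within the data shown here, no measured step shows what such a change does, and in neither direction is a step beyond the scatter expected in this assay, because compound 2 shows > 50000 nM. The assay may well report only a limit again. For compound 3 the expected value is 50000 nM, with an estimated range from 25000 nM to 100000 nM.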

Compound 3, half-maximal inhibitory concentration: > 50000 nM
Compound 3 ended at the assay's limit; the forecaster's own chance of this, stated with the estimate: 80%; the middle value sits exactly at the limit.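

Compound 3 gives > 50000 nM, which is a limit and not a number. Within the data shown here, no new step can therefore be read between compound 3 and either compound 1 or compound 2. The actual standing of these compounds in this assay stays open: the limit of > 50000 nM in this assay, at which 2 of the 3 values shown sit.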